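The compounds below may be only part of what the source reports. "The series", "measured", "known", "first", "only" and "open" are said of these compounds alone.

Compound 1 `N#C/C(=C\c1c(-c2ccccc2)[nH]c2ccccc12)C(=O)c1ccccc1` and compound 2 `O=C(/C(=C\c1c(-c2ccccc2)[nH]c2ccccc12)S(=O)(=O)c1ccccc1)c1ccccc1` share a core and differ in the group attached to the exocyclic double bond. In a functional assay on COLO 205 cells (Homo sapiens) for inhibition, read by sulforhodamine B assay, with a stated time of 48 h (on this read-out lower numbers stand for stronger inhibition of growth and higher numbers for weaker inhibition of growth), compound 1 gives 5000 nM, and in the same assay compound 2 gives 7800 nM. Compound 2 thus carries the higher of the two numbers, yet the gap to compound 1 lies within the scatter, so the two cannot be told apart on these data. Compound 3 `CC(=O)/C(=C\c1c(-c2ccccc2)[nH]c2ccccc12)S(=O)(=O)c1ccccc1` has not yet been measured. It differs from compound 2 in one place: methyl in place of phenyl on a carbonyl carbon. For the measured compounds named here, no measured pair shows the effect of this change, so there is no step to lean on. On that basis the step from compound 2 to compound 3 is expected to be small, a 1.4-fold higher number from compound 2 to compound 3 (0.15 log units; within the scatter), if anything toward a weaker inhibition. Compound 3 is therefore estimated at 11000 nM, with a range from 3500 nM to 35000 nM.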

Compound 3, concentration for 50% growth inhibition: 1700 nM
The estimate for compound 3 lay 6.5-fold (0.81 log units) above the measured number; measured number outside the range, below it.
By their numbers in this assay, from the lowest: compound 3; then compounds 1 and 2 (each within the scatter of the next).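

For the compounds shown here, the benzoyl to acetyl change gives the first step here that lies beyond the scatter: in this assay, methyl in place of phenyl on the carbonyl carbon gives a 4.6-fold lower number from compound 2 to compound 3 (0.66 log units; beyond the scatter). This position therefore responds to the group it carries, and in this one pair the single carbon of methyl, rather than the six-carbon aromatic ring of phenyl, goes with the stronger inhibition of growth. Nothing at hand bears on what lies behind this step.

From the compounds shown here alone, with a single step at this position, it remains open whether a longer chain such as ethyl or propyl, or an amine, on the carbonyl carbon would keep the lower number. Going by these compounds, it is equally open whether the same change would give a similar step on compound 1, which carries the nitrile.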